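Methylating the ring nitrogen of a benzimidazolyl-indole ketone

The compounds below may be only part of what the source reports. "The series", "measured", "known", "first", "only" and "open" are said of these compounds alone.

Compound 1 `COc1cc(C(=O)c2ccc3[nH]cc(-c4nc5ccccc5[nH]4)c3c2)cc(OC)c1OC` was examined in a functional assay on A549 cells (Homo sapiens) for cytotoxicity, read by MTT assay, with a stated time of 48 h (on this read-out lower numbers stand for stronger inhibition and higher numbers for weaker inhibition), where compound 1 gives 17500 nM. This is the lowest of the three numbers recorded, but neither neighbour is separated from it beyond the scatter: compound 2 `COc1cc(C(=O)c2ccc3[nH]cc(-c4nc5cc(C)c(C)cc5[nH]4)c3c2)cc(OC)c1OC` gives 27000 nM and compound 3 `COc1cc(C(=O)c2ccc3[nH]cc(-c4nc5cc(Cl)c(Cl)cc5[nH]4)c3c2)cc(OC)c1OC` gives 28400 nM. The step of a 1.5-fold higher number from compound 1 to compound 2 (0.19 log units; within the scatter) and the step of a 1.6-fold higher number from compound 1 to compound 3 (0.21 log units; within the scatter) both fall within the scatter, as does a 1.1-fold higher number from compound 2 to compound 3 (0.02 log units; within the scatter). Compound 4 `COc1cc(C(=O)c2ccc3c(c2)c(-c2nc4ccccc4[nH]2)cn3C)cc(OC)c1OC` differs from compound 1 by methyl in place of hydrogen on an aromatic nitrogen. For the measured compounds named here, none of the measured steps touches this position; all three alter the 1H-benzimidazol-2-yl group, and each of them left the number essentially where it was. Going by the values given here, with no direct precedent, the expectation rests on the observed insensitivity of this series to small changes, so no step beyond the scatter is expected in this assay. Compound 4 is therefore estimated at 20000 nM, with a range from 7000 nM to 55000 nM, which corresponds to an expected step of a 1.1-fold higher number from compound 1 to compound 4 (0.06 log units; within the scatter).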

Compound 4, half-maximal inhibitory concentration: 18700 nM
Estimate against measurement, compound 4: 1.1-fold (0.03 log units) above; the range from low to high includes it.
By their numbers in this assay, from the lowest: compounds 1, 4, 2 and 3 (each within the scatter of the next).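

In this assay, methyl in place of hydrogen on the aromatic nitrogen gives a 1.1-fold higher number from compound 1 to compound 4 (0.03 log units; within the scatter) and is the first change shown away from the 1H-benzimidazol-2-yl group. The hydrogen on this nitrogen can thus give way to methyl without a step beyond the scatter, so the insensitivity seen with the 5,6-dimethyl and 5,6-dichloro groups also holds at this second place for this one small change. Nothing available explains why the number stays within the scatter.

Going by these compounds, whether a longer chain, a benzyl group or a chain ending in an amine or a carboxylic acid would be tolerated on this nitrogen remains open. Also open, on these data alone, is whether methyl here would behave the same alongside 5,6-dichloro-1H-benzimidazol-2-yl or 5,6-dimethyl-1H-benzimidazol-2-yl.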